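The source may report more compounds than this note shows. Statements on the series, on what has been measured and on what is new or still open speak of the compounds shown alone.

Measured compounds:
compound 1 `CCCS(=O)(=O)Nc1ccc(F)c(C(=O)c2n[nH]c3ncc(-c4cccc(C)c4)cc23)c1F`, 15%
compound 2 `CCCS(=O)(=O)Nc1ccc(F)c(C(=O)c2n[nH]c3ncc(-c4ccc(F)cc4C)cc23)c1F`, 14%

In an assay for binding affinity to dual specificity mitogen-activated protein kinase kinase 4 (Homo sapiens), read by KINOMEscan, tested at 100 nM (on this read-out lower numbers stand for a stronger effect and higher numbers for a weaker effect at the one concentration tested), compound 2 stands lowest of the two numbers, with compound 1 nearest and within the scatter. Compound 3 `CCCS(=O)(=O)Nc1ccc(F)c(C(=O)c2n[nH]c3ncc(-c4ccc([N+](=O)[O-])cc4)cc23)c1F` differs from compound 2 by 4-nitrophenyl in place of 4-fluoro-2-methylphenyl on an aromatic carbon. Among the compounds with values here, the only measured step, a number 1 percentage points lower from compound 1 to compound 2 (within the scatter), also exchanged one aryl group for another and stayed within the scatter, so it offers little guidance for an aryl group with two hydrogen-bond acceptors. No step beyond the scatter is therefore firmly expected in this assay, though the uncertainty is wide. The estimate for compound 3 is 22%, between 6% and 55%. The expected step is a number 8 percentage points higher from compound 2 to compound 3 (within the scatter).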

Compound 3, a percentage reported as activity, at one concentration (the size of the read-out at that concentration, not a potency): 4.2%
Beside the measured number, compound 3's estimate is 17.8 percentage points above it, and the stated range ends above it.
By their numbers in this assay, from the lowest: compounds 3, 2 and 1 (each within the scatter of the next, the first and the last beyond it).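

In this assay, the aryl position on the shared core tolerates 4-nitrophenyl, which has 2 hydrogen-bond acceptors where the earlier aryl groups had none: the change gives a number a number 9.8 percentage points lower from compound 2 to compound 3 (within the scatter) and a number a number 10.8 percentage points lower from compound 1 to compound 3 (beyond the scatter). Within the data shown here, the second step is the first at this position to lie beyond the scatter, so the aryl group here can change the read-out. No evidence is available to explain this difference. As far as these compounds go, it remains open whether the nitro group itself or the absence of a methyl group matters, and whether a 4-aminophenyl or 4-carboxyphenyl group would give a similar number.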